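Piperidinyl for dipropylamino on a methoxy-bearing aniline ring

The source may report more compounds than this note shows. Statements on the series, on what has been measured and on what is new or still open speak of the compounds shown alone.

Compound 1 `CCCN(CCC)c1ccc(Nc2ncc(Cl)c(Oc3cccc(NC(=O)CC)c3)n2)cc1` gives 9.3% in an assay on isolated protein for inhibition of NUAK family SNF1-like kinase 1 (Homo sapiens), read by ADP-Glo, with a stated time of 60 min, tested at 10 uM, in the presence of a further agent that is not named here; a higher number here means more inhibition at the concentration tested (going by the name of the read-out), a lower number less inhibition. Compound 2 `CCC(=O)Nc1cccc(Oc2nc(Nc3ccc(N4CCCCC4)cc3)ncc2Cl)c1` carries piperidin-1-yl in place of dipropylamino on an aromatic carbon and gives 86%; the step of a number 76.7 percentage points higher from compound 1 to compound 2 (beyond the scatter) is large. Compound 3 `CCCN(CCC)c1ccc(Nc2ncc(Cl)c(Oc3cccc(NC(=O)CC)c3)n2)c(OC)c1` differs from compound 1 by methoxy in place of hydrogen on an aromatic carbon, and in this assay compound 3 is reported as "not active" (no number reported), without a number. Compound 4 `CCC(=O)Nc1cccc(Oc2nc(Nc3ccc(N4CCCCC4)cc3OC)ncc2Cl)c1` is not yet measured; it differs from compound 3 by piperidin-1-yl in place of dipropylamino on an aromatic carbon, the same kind of change as that from compound 1 to compound 2, but here the place is meta to a methoxy group as well as para to a large group. Since the same kind of change gave the large step of a number 76.7 percentage points higher from compound 1 to compound 2 (beyond the scatter), a rise of comparable direction from compound 3 to compound 4 is expected, yet the absence of a number for compound 3 and its report as not active leave the starting level uncertain, so the expectation is held wide. In this assay compound 4 is estimated to give 45%, with a range from 10% to 85%.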

Compound 4, a percentage reported as inhibition, at one concentration (the size of the read-out at that concentration, not a potency): 13.9%
The estimate for compound 4 lay 31.1 percentage points above the measured number; the measured number falls inside the stated range.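

In this assay, methoxy in place of hydrogen on an aromatic carbon of the piperidin-1-yl series gives a number 72.1 percentage points lower from compound 2 to compound 4 (beyond the scatter), so on this core the change removes most of the inhibition that compound 2 shows. The same methoxy change on the dipropylamino core, from compound 1 to compound 3, and the piperidin-1-yl change between the two methoxy-bearing compounds cannot be read as steps, since compound 3 stands only as "not active" (no number reported); the report of compound 3 sits comfortably with a loss there too, but it does not show that the change has the same size on both cores. Nothing given here bears on why the step is so large.

The compounds shown leave open whether the loss belongs to methoxy alone or would also follow from fluorine or ethoxy in its place. They also leave open whether morpholin-4-yl in place of piperidin-1-yl would behave the same way with and without the methoxy group.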